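Esterification step in the oxazole ketone series

The source may report more compounds than this note shows. Statements on the series, on what has been measured and on what is new or still open speak of the compounds shown alone.

Compound 1 `COC(=O)c1cc(-c2cnc(C(=O)CCc3ccc(-c4ccccc4)cc3)o2)ccn1` and compound 2 `O=C(O)c1cc(-c2cnc(C(=O)CCc3ccc(-c4ccccc4)cc3)o2)ccn1` share one core and differ only at the acid group: methyl in place of hydrogen on an oxygen next to a carbonyl group. In an assay for inhibition of Fatty-acid amide hydrolase 1 (Rattus norvegicus) (on this read-out lower numbers stand for stronger inhibition and higher numbers for weaker inhibition), compound 1 gives 1.5 nM, while compound 2 gives 50 nM; the step is a 33-fold lower number from compound 2 to compound 1 (1.52 log units; beyond the scatter). Compound 3 `O=C(O)c1cccc(-c2cnc(C(=O)CCc3ccc(-c4ccc(CN5CCCCC5)cc4)cc3)o2)n1` carries a second core; the difference between the two cores is not broken down here. In this assay compound 3 gives 44 nM, which sits close to compound 2 and well away from compound 1.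

Compound 4 `COC(=O)c1cccc(-c2cnc(C(=O)CCc3ccc(-c4ccc(CN5CCCCC5)cc4)cc3)o2)n1` has not been measured. It stands to compound 3 as compound 1 stands to compound 2: methyl in place of hydrogen on an oxygen next to a carbonyl group. The place of the change is described in the same words for both pairs, an oxygen next to a carbonyl group whose other neighbours are the carbonyl carbon, so this is the same change made on the second core; cut one bond further out it reads 6-carboxypyridin-2-yl to 6-(methoxycarbonyl)pyridin-2-yl here, against 2-carboxypyridin-4-yl to 2-(methoxycarbonyl)pyridin-4-yl in the first pair.

Within the data shown here, the expectation for compound 4 in this assay is therefore a step of a 22-fold lower number from compound 3 to compound 4 (1.34 log units; beyond the scatter), a large drop of the same order as the one seen from compound 2 to compound 1, because that pair gave a 33-fold lower number from compound 2 to compound 1 (1.52 log units; beyond the scatter). This rests on a single measured pair, with the two cores differing in other ways, so the range is kept wide. Compound 4 is estimated at 2 nM, expected between 0.6 nM and 8 nM.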

Compound 4, inhibition constant: 9 nM
For compound 4 the middle estimate is 4.5-fold (0.65 log units) below the measured one; the whole stated range lies below it.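

In this assay, methyl in place of hydrogen on an oxygen next to a carbonyl group again lowers the number on the second core, with a 4.9-fold lower number from compound 3 to compound 4 (0.69 log units; beyond the scatter), so the direction of the change carries over from one core to the other. The size does not carry over, and the ester gain on the second core is clearly smaller than on the first: the same change on two cores in this assay, a 33-fold lower number (1.52 log units; beyond the scatter) from compound 2 to compound 1 and a 4.9-fold lower number (0.69 log units; beyond the scatter) from compound 3 to compound 4, 6.8-fold (0.83 log units) apart, beyond the scatter of two such steps What this does not show is which feature of the cores sets the size of the step, since they differ in more than one place, and two pairs give no basis for a general rule or for predicting the step on a further core.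

Still open, as far as these compounds go, is whether the 6-carboxypyridin-2-yl versus 2-carboxypyridin-4-yl difference or the piperidine-bearing end of compound 3 and compound 4 accounts for the gap, which would take a pair differing in only one of these features. Also open, from the compounds shown here alone, is whether an ethyl ester or a primary amide in place of the methyl ester would follow the same direction on either core, and how large that step would be.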